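Replacing a Phenyl Group on the Amide Nitrogen

A few compounds are considered here, and "the series" means these few. Any claim that something is new, unique, unknown or untested is made for them only; others in the source may bear on it.

Compounds measured so far:
- compound 1, `Cc1cc(C)cc(NC(=O)COc2cc(C)nc3ccc(OCc4ccccc4)cc23)c1` — > 100000 nM
- compound 2, `COc1ccc2nc(C)cc(NCC(=O)Nc3cc(C)cc(C)c3)c2c1` — 6310 nM
- compound 3, `COc1ccc2nc(C)cc(OCC(=O)Nc3ccccc3)c2c1` — 39800 nM

All three were tested in a toxicity assay on HepG2 cells (Homo sapiens) for inhibition, read by CellTiter-Glo, with a stated time of 48 h; on this read-out higher numbers stand for weaker inhibition and lower numbers for stronger inhibition. For compound 1 the assay reports only a limit, > 100000 nM, not a number. Compound 2 gives 6310 nM. Compound 3 gives 39800 nM, the higher of the two numbers, so among the compounds with a number it is the weaker inhibitor of these cells, and its gap to compound 2 lies beyond the usual scatter.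

Compound 4, `COc1ccc2nc(C)cc(OCC(=O)NC3CONC3=O)c2c1`, is not yet measured. It differs from compound 3 in one place: a group of 6 heavy atoms (3 carbon, 1 nitrogen, 2 oxygen; one five-membered non-aromatic ring with 2 hetero atoms) in place of a group of 6 heavy atoms (6 carbon; one six-membered aromatic ring of carbon only), on an amide-type nitrogen. Among the measured compounds shown here, no measured pair shows this kind of change, so the size of its effect is open. The expectation is a step toward a higher number, so weaker inhibition, though the number may again end at a limit. Compound 4 is therefore estimated at 80000 nM, within a range from 20000 nM to 300000 nM, which means an expected step of a 2.0-fold higher number from compound 3 to compound 4 (0.30 log units; within the scatter).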

Compound 4, half-maximal inhibitory concentration: > 100000 nM
Compound 4 ended at the assay's limit; the forecaster's own chance of this, stated with the estimate: 45%; middle value at least 1.2-fold (0.09 log units) from the limit.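

In this assay, replacing the phenyl on the amide-type nitrogen with the five-membered non-aromatic ring gives an at least 2.5-fold higher number from compound 3 to compound 4 (0.40 log units; beyond the scatter). Among the compounds shown here, the earlier compounds offered no pair differing in one place, so this is the first direct sign that the group on this nitrogen matters: this change moves the read-out beyond the scatter, toward weaker inhibition of these cells. The true size of the step stays unknown, since the value of compound 4 is a limit and not a number: the limit of > 100000 nM in this assay, at which 2 of the 4 values shown sit.

This single swap changes the ring size, the aromatic character and the hetero atoms all at once, so the compounds shown cannot say which of these matters. They also leave open how a cyclohexyl ring, a pyridine ring or a short chain ending in an amine would behave here.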